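Swapping the Five-Membered Ring Once More

This account rests on a few compounds, and the source may have more. Where it says the series, first, only, none or still open, it means among the compounds named here.

Going by the values given here, compound 2 `Cc1cc(-c2ccccc2OCC2=NCCN2)sn1` gives 158 nM in a functional assay for activation of Alpha-1A adrenergic receptor (Homo sapiens), read by calcium flux (on this read-out lower numbers stand for an effect already at smaller amounts and higher numbers for an effect only at larger amounts of compound), the higher of the two numbers measured so far; the nearest is compound 1 `Cc1ccc(-c2ccccc2OCC2=NCCN2)s1` with 25.1 nM. Among the compounds with values here, the single measured step, a 6.3-fold higher number from compound 1 to compound 2 (0.80 log units; beyond the scatter), is the only one that bears here, as it too swapped one five-membered aromatic ring for another. Compound 3 `Cn1nccc1-c1ccccc1OCC1=NCCN1` carries 1-methyl-1H-pyrazol-5-yl in place of 3-methyl-1,2-thiazol-5-yl on an aromatic carbon. A step of similar, modest size is therefore expected in this assay, most likely toward a higher number, though a step within the scatter cannot be excluded. The expected step is a 1.9-fold higher number from compound 2 to compound 3 (0.28 log units; within the scatter). Compound 3 is estimated at 300 nM, within 90 nM to 1000 nM.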

Compound 3, half-maximal effective concentration: 39.8 nM
Compound 3: the middle estimate sits 7.5-fold (0.88 log units) above what was measured, outside the stated range (below it).
By their numbers in this assay, from the lowest: compounds 1 and 3 (each within the scatter of the next); then compound 2.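

In this assay, this position distinguishes between five-membered rings even when the count of heavy atoms and hetero atoms stays the same (a 4.0-fold lower number from compound 2 to compound 3 (0.60 log units; beyond the scatter)). The 1-methyl-1H-pyrazol-5-yl group holds no sulfur, yet it stays within the scatter of the 5-methylthiophen-2-yl group (a 1.6-fold higher number from compound 1 to compound 3 (0.20 log units; within the scatter)), so sulfur is not required for a low number here. No measured evidence explains these differences. Still open, going by these compounds, is how an amine or a longer chain in place of the methyl on the five-membered ring would read in this assay.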